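A few compounds are considered here, and "the series" means these few. Any claim that something is new, unique, unknown or untested is made for them only; others in the source may bear on it.

Measured compounds in the series so far:

Compound 1 `CCN(CC)c1cc2[nH]c(C3CCCCC3)nc2cc1NC(=O)c1cnccn1`: in an ADME assay on Vero cells (Chlorocebus sabaeus) for cytotoxicity, read by resazurin assay, with a stated time of 3 days (a higher number here means a weaker inhibitor, a lower number a stronger inhibitor), compound 1 gives > 100 ug/mL, which is a limit of the assay and not a number.
Compound 2 `CCN(CC)c1cc2[nH]c(C3CCCCC3)nc2cc1NC(=O)c1ccc(N(C)C)cc1`: in this assay compound 2 gives "not determined" (no result reported).
Compound 3 `CCN(CC)c1cc2[nH]c(C3CCCCC3)nc2cc1NC(=O)c1ccc(F)cc1`: in this assay compound 3 gives > 100 ug/mL, also a limit of the assay.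

Compound 3 therefore stands only at a limit; of the other two entries, one is also a limit and one carries no number. Among the measured compounds shown here, the single measured step, a step that the two limits leave unreadable from compound 1 to compound 3, is unreadable because of the limit of > 100 ug/mL in this assay, at which 2 of the 3 values shown sit.

Compound 4 `CCOc1ccc(C(=O)Nc2cc3nc(C4CCCCC4)[nH]c3cc2N(CC)CC)cc1` is the next member to be tested. It differs from compound 3 as follows: ethoxy in place of fluoro on an aromatic carbon. No measured step touches this change; the one step shown is unreadable, so it gives no size or direction to lean on. The working expectation is that compound 4 behaves like compound 3 and also reaches the limit, so the step of a number no higher from compound 3 to compound 4 (the limit leaves the size open) is expected to be none beyond the scatter. The estimate for compound 4 in this assay is 100 ug/mL, expected between 50 ug/mL and 200 ug/mL.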

Compound 4, half-maximal inhibitory concentration: > 100 ug/mL
Compound 4: only a limit was reported; the forecaster's own chance of this, stated with the estimate: 80%; the middle value lies on the limit itself.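

No new step can be read from compound 4 to compound 3 or compound 1, because the values of all three are limits of the assay and not numbers: the limit of > 100 ug/mL in this assay, at which 3 of the 4 values shown sit.

The compounds shown leave open whether compound 1, compound 3 and compound 4 differ at all in this assay, and where compound 2 stands there.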